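From 3-Chlorophenyl to 4-Chlorophenyl on an Amide Nitrogen

The compounds below may be only part of what the source reports. "The series", "measured", "known", "first", "only" and "open" are said of these compounds alone.

Three compounds have been measured in a functional assay on KB cells (Homo sapiens) for inhibition, read by MTT assay, with a stated time of 24 h, tested at 0.1 ug/mL; a lower number here means less inhibition of growth, a higher number more inhibition of growth at the concentration tested:

Compound 1, `CC(=O)SCCC(CCCCC(=O)Nc1cccc(Cl)c1)SC(C)=O`, gives 5.72%.
Compound 2, `CC(=O)SCCC(CCCCC(=O)Nc1ccc(Cl)cc1)SC(C)=O`, gives 11.4%.
Compound 3, `O=C(CCCCC(CCSC(=O)c1ccccc1)SC(=O)c1ccccc1)Nc1cccc(Cl)c1`, gives 10.7%.

Compound 1 and compound 2 share a core and differ in one place: 4-chlorophenyl in place of 3-chlorophenyl on an amide-type nitrogen. That change gives a number 5.7 percentage points higher from compound 1 to compound 2 (within the scatter), so the two numbers cannot be told apart in this assay. Compound 3 rests on a different core; how its core differs from that of compound 1 is not broken down here. Its value sits close to that of compound 2 and also close to that of compound 1, all three within the usual scatter of one another, so no order among them can be claimed.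

Compound 4, `O=C(CCCCC(CCSC(=O)c1ccccc1)SC(=O)c1ccccc1)Nc1ccc(Cl)cc1`, has not yet been measured. It differs from compound 3 in one place: 4-chlorophenyl in place of 3-chlorophenyl on an amide-type nitrogen. Among the measured compounds shown here, this is the same change as the one from compound 1 to compound 2, made at the same kind of place on the other core. Because the earlier change gave a number 5.7 percentage points higher from compound 1 to compound 2 (within the scatter), the step from compound 3 to compound 4 is expected to be small as well, estimated at a number 3.3 percentage points higher from compound 3 to compound 4 (within the scatter). The only support for this expectation is that single pair, so it rests on one observation. Compound 4 is accordingly expected to give about 14%, with a likely range from 4% to 25%.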

Compound 4, percent growth inhibition at one concentration: 17%
Estimate against measurement, compound 4: 3 percentage points below, and the stated range covers the measured number.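

In this assay, putting 4-chlorophenyl in place of 3-chlorophenyl on the amide-type nitrogen of the core of compound 3 gives a number 6.3 percentage points higher from compound 3 to compound 4 (within the scatter), so these two compounds cannot be told apart. Set beside the earlier pair, the change reads alike on the two cores: the same change on two cores in this assay, a number 5.7 percentage points higher (within the scatter) from compound 1 to compound 2 and a number 6.3 percentage points higher (within the scatter) from compound 3 to compound 4, 0.6 percentage points apart, within the scatter of two such steps. This shows that the step stays within the scatter on both cores, but it does not show that 4-chlorophenyl truly gives more inhibition of growth than 3-chlorophenyl, and two pairs set no rule for other cores in the series.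

The compounds shown carry only a chlorophenyl group on the amide-type nitrogen and only acetyl or benzoyl groups on the two sulfur atoms, so it remains open whether the change would read alike with free thiols in place of those thioesters, or with a longer chain in the core. Also open, going by these compounds, is how a fluorophenyl or methoxyphenyl group on that nitrogen would compare, and whether any difference between such groups would stand clear of the scatter in this assay.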